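Secondary amine in place of one pyridylmethyl arm

The source may report more compounds than this note shows. Statements on the series, on what has been measured and on what is new or still open speak of the compounds shown alone.

Three compounds on a shared core have been run through a functional assay on cells for antagonist activity at C-X-C chemokine receptor type 4 (Homo sapiens), read by fluorescence and calcium flux, with stated times of 25 min and 90 s; a higher number here means a weaker inhibitor, a lower number a stronger inhibitor. Compound 1 `c1ccc(CN(CCCCN(C[C@H]2Cc3ccccc3CN2)[C@H]2CCCc3cccnc32)Cc2ccccn2)nc1` gives 664 nM. Compound 2 `c1ccc2c(c1)CN[C@@H](CN(CCCCN(Cc1ccncc1)Cc1ccncc1)[C@H]1CCCc3cccnc31)C2` gives 832 nM, the highest of the two numbers read out, with compound 1 the nearest neighbour and the gap between the two falling within the scatter of the method. Compound 3 `c1ccc(CN(CCCCN(C[C@H]2Cc3ccccc3CN2)[C@H]2CCCc3cccnc32)Cc2ccccc2)cc1` gives only a limit, > 16700 nM, so no number is known for it; this is the limit of > 16700 nM in this assay, at which 1 of the 3 values shown sits. Taken together, the two pyridylmethyl-bearing compounds sit in the same band while the dibenzyl compound 3 falls out of range.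

Compound 4 `c1ccc2c(c1)CN[C@@H](CN(CCCCNCc1ccncc1)[C@H]1CCCc3cccnc31)C2` has not yet been measured. It differs from compound 2 by hydrogen in place of (pyridin-4-yl)methyl on an amine nitrogen. Within the data shown here, no step of this kind is available among the measured compounds, so the direction rests on the general picture: the two numbered compounds both carry two pyridylmethyl arms on that amine, and nothing here shows what a single arm does. A modest loss in this assay is expected, of a size around a 2.6-fold higher number from compound 2 to compound 4 (0.42 log units; beyond the scatter), rather than a change within the scatter. Compound 4 is therefore estimated at 2200 nM, with a plausible range from 600 nM to 9000 nM.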

Compound 4, half-maximal inhibitory concentration: 22.7 nM
For compound 4 the middle estimate is 97-fold (1.99 log units) above the measured one; measured number outside the range, below it.
By their numbers in this assay, from the lowest: compound 4; then compounds 1 and 2 (each within the scatter of the next). At a limit, above all of these: compound 3.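

In this assay, hydrogen in place of (pyridin-4-yl)methyl on an amine nitrogen gives a 37-fold lower number from compound 2 to compound 4 (1.56 log units; beyond the scatter), a large change in favour of the compound with a single arm. The earlier compounds shown here all carried two arms on this nitrogen, so they could not show that the second (pyridin-4-yl)methyl is dispensable here, or that its removal brings a gain far beyond the scatter rather than a loss. The data shown contain no measurement that accounts for the size of this step.

Still open, on these data alone, is whether the gain depends on the remaining (pyridin-4-yl)methyl arm or carries over to the pyridylmethyl arms of compound 1, since this is a single pair on one arm type. Also unresolved is how far the nitrogen can be stripped down, for instance whether a small methyl group on it, or a primary amine at the end of the chain with no arm at all, would hold the activity seen for compound 4 at 22.7 nM.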